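Purine nucleoside series: methylamino in place of methylsulfanyl

This account rests on a few compounds, and the source may have more. Where it says the series, first, only, none or still open, it means among the compounds named here.

Within the data shown here, compound 2 `CSc1nc(SC)c2ncn([C@@H]3C[C@@H](O)[C@H](CO)O3)c2n1` is the only member with a number in a functional assay on NALL-1 cells (Homo sapiens); on this read-out lower numbers stand for stronger inhibition and higher numbers for weaker inhibition; compound 2 gives 173 uM. Compound 1 `CN(C)c1nc(N)c2ncn([C@@H]3C[C@@H](O)[C@H](CO)O3)c2n1` reaches only the assay limit of > 300 uM in this assay, as the limit of > 300 uM in this assay, at which 1 of the 2 values shown sits, records. Compound 3 `CNc1nc(SC)nc2c1ncn2[C@@H]1C[C@@H](O)[C@H](CO)O1` awaits measurement; it differs from compound 2 by methylamino in place of methylsulfanyl on an aromatic carbon. No measured step sizes this change, so a shift toward weaker inhibition, slightly beyond the scatter, is expected because compound 1 sits at > 300 uM. Compound 3 is estimated at 260 uM, within 80 uM to 900 uM. The expected step is a 1.5-fold higher number from compound 2 to compound 3 (0.18 log units; within the scatter).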

Compound 3, concentration for 50% inhibition: 186 uM
For compound 3 the middle estimate is 1.4-fold (0.15 log units) above the measured one; low and high end bracket the measured number.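

In this assay, methylamino in place of methylsulfanyl on the aromatic carbon next to the ring nitrogen gives a 1.1-fold higher number from compound 2 to compound 3 (0.03 log units; within the scatter). This first sized step at the position shows that the exchange, which adds a hydrogen-bond donor, does not separate the two compounds on this read-out. Compound 1 remains outside any comparison, as its entry is a limit of the assay: the limit of > 300 uM in this assay, at which 1 of the 3 values shown sits.

On these data alone, whether methoxy or a longer chain such as propylamino at this position would move the number beyond the scatter stays open. As far as these compounds go, the effect of exchanging the remaining methylsulfanyl group of compound 3 alone also stays open.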